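The compounds below may be only part of what the source reports. "The series", "measured", "known", "first", "only" and "open" are said of these compounds alone.

Measured so far:
compound 1 `COC(=O)c1ccc(NCc2cncn2Cc2ccccc2Br)cc1-c1ccccc1` — 10000 nM
compound 2 `COC(=O)c1ccc(NCc2cncn2Cc2ccc(F)cc2)cc1-c1ccccc1` — "not determined" (no result reported)

In a toxicity assay on NIH3T3 cells (Mus musculus) for cytotoxicity, read by resazurin assay (on this read-out lower numbers stand for an effect already at smaller amounts and higher numbers for an effect only at larger amounts of compound), compound 1 gives 10000 nM. For compound 2 the same test gives "not determined" (no result reported), so compound 2 stands without a number of its own, and the step to compound 3 `COC(=O)c1ccc(NCc2cncn2Cc2ccccc2C#N)cc1-c1ccccc1` cannot be anchored on it. The change is 2-cyanophenyl in place of 4-fluorophenyl on a saturated chain carbon bound to an aromatic nitrogen. For the measured compounds named here, with no measured step to lean on, no change beyond the scatter is expected in this assay; the only available value, that of compound 1, points to weak cytotoxicity across the shared core. Compound 3 is therefore estimated at 10000 nM, expected within 3000 nM to 30000 nM.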

Compound 3, half-maximal effective concentration: 25000 nM
The estimate for compound 3 lay 2.5-fold (0.40 log units) below the measured number; low and high end bracket the measured number.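

For the compounds shown here, this position is not silent: in this assay, cyano in place of bromo on an aromatic carbon gives a 2.5-fold higher number from compound 1 to compound 3 (0.40 log units; beyond the scatter), the first readable step. The change from 4-fluorobenzyl to 2-cyanobenzyl cannot be read, as compound 2 has no number of its own. Nothing at hand accounts for the shift. Open, going by these compounds, is where a benzyl group carrying an amine or a carboxylic acid in place of the cyano would stand in this assay, and whether the step carries over to other cores.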